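Hydroxymethyl in place of ethoxycarbonyl: notes on compound 4

A few compounds are considered here, and "the series" means these few. Any claim that something is new, unique, unknown or untested is made for them only; others in the source may bear on it.

Values below come from a functional assay on HeLa cells (Homo sapiens) for cytotoxicity, read by MTT assay, with a stated time of 48 h; on this read-out lower numbers stand for stronger inhibition and higher numbers for weaker inhibition
compound 1 `COc1cc([C@@H]2C[C@@]2(CO)C(=O)Nc2ccccc2)cc(OC)c1OC` | 86400 nM
compound 2 `CCOC(=O)[C@@]1(C(=O)Nc2ccccc2)C[C@@H]1c1cc(OC)c(OC)c(OC)c1` | > 100000 nM (a limit)
compound 3 `CCOC(=O)C1(C(=O)Nc2ccccc2)CC1c1cc(OC)c(OC)c(OC)c1` | > 100000 nM; > 100000 nM (2 entries) (a limit)

Compound 2 stands only at a limit, > 100000 nM and not a number. The change to compound 4 `COc1cc([C@H]2C[C@@]2(CO)C(=O)Nc2ccccc2)cc(OC)c1OC` is hydroxymethyl in place of ethoxycarbonyl on a saturated ring carbon with hydroxymethyl in place of ethoxycarbonyl on a saturated ring carbon. Among the measured compounds shown here, no step with numbers at both ends exists, so the size of this one cannot be read from earlier pairs. For the measured compounds named here, compound 1 also carries hydroxymethyl and gives 86400 nM as the only number, so a modest move toward lower numbers is expected in this assay and not a large one. The estimated change is an at least 1.4-fold lower number from compound 2 to compound 4 (0.15 log units; that floor lies within the scatter) and it stays rough. A second limit for compound 4 would not be a surprise. The expected value for compound 4 is 70000 nM with an estimated range from 25000 nM to 100000 nM in this read-out.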

Compound 4, half-maximal inhibitory concentration: > 100000 nM
Compound 4: a limit, no number (the forecaster's own chance of this, stated with the estimate: 35%); middle value at least 1.4-fold (0.15 log units) from the limit.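

In this assay, compound 4 carries hydroxymethyl and still gives only a limit, so hydroxymethyl in place of ethoxycarbonyl on a saturated ring carbon does not by itself guarantee a readable number, and the step between the two limits cannot be read. Among the compounds shown here, the series now holds a pair that isolates configuration, which the earlier compounds did not offer: the fact that compounds 1 and 4 differ only in the configuration as drawn. The one readable step is an at least 1.1-fold higher number from compound 1 to compound 4 (0.06 log units; that floor lies within the scatter), so a real difference between the two configurations is neither shown nor excluded.

From the compounds shown here alone, how far compound 4 lies past its limit remains open, and with it the true size of any configuration effect. Also open, going by these compounds, is whether an amine or a carboxylic acid on this saturated ring carbon would give a clearly lower number than hydroxymethyl.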